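The source may report more compounds than this note shows. Statements on the series, on what has been measured and on what is new or still open speak of the compounds shown alone.

Among the measured compounds shown here, in a functional assay on HepG2 cells (Homo sapiens) for antiproliferative activity, read by MTT assay, with a stated time of 48 h (a higher number here means a weaker inhibitor, a lower number a stronger inhibitor), compound 1 `COc1ccccc1CNc1ccc2ncnc(Nc3cccc(Br)c3)c2c1` gives 8820 nM, the higher of the two numbers so far, and compound 2 `Brc1ccc(CNc2ccc3ncnc(Nc4cccc(Br)c4)c3c2)cc1` gives 1410 nM. Compound 3 `COc1ccc(CNc2ccc3ncnc(Nc4cccc(Br)c4)c3c2)cc1` remains unmeasured. It carries 4-methoxyphenyl in place of the 2-methoxyphenyl of compound 1, on a saturated chain carbon bound to a nitrogen on an aromatic ring: 4-methoxyphenyl in place of 2-methoxyphenyl on a saturated chain carbon bound to a nitrogen on an aromatic ring. For the measured compounds named here, the only measured step bearing on this, a 6.3-fold lower number from compound 1 to compound 2 (0.80 log units; beyond the scatter), has the same group leaving but 4-bromophenyl entering, so a smaller step towards a lower number is expected in this assay. The expected step is a 2.5-fold lower number from compound 1 to compound 3 (0.40 log units; beyond the scatter). For compound 3 the estimated value is 3500 nM, with an expected range of 1300 nM to 8800 nM.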

Compound 3, half-maximal inhibitory concentration: 5430 nM
Estimate against measurement, compound 3: 1.6-fold (0.19 log units) below; measured number inside the range.
By their numbers in this assay, from the lowest: compound 2; then compounds 3 and 1 (each within the scatter of the next).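

In this assay the exchange of 2-methoxyphenyl for 4-methoxyphenyl gives a 1.6-fold lower number from compound 1 to compound 3 (0.21 log units; within the scatter), so these two placements of methoxy are not separated here. With the placement held fixed, methoxy in place of bromo on an aromatic carbon gives a 3.9-fold higher number from compound 2 to compound 3 (0.59 log units; beyond the scatter), so this exchange alone carries a step beyond the scatter, which the earlier pair, differing in both group and placement, could not show. Nothing on hand speaks to the reason for this difference.

Still open, going by these compounds, is how an amine or a carboxylic acid would compare with bromo on that aromatic carbon. Also open, on these data alone, is whether bromo, like methoxy, shows no separation between the two placements.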